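Amide nitrogen variation on the shared core

The source may hold more compounds than are shown below. What is called first, only, known or untested is meant among the compounds shown, and "the series" means these compounds.

Compound 1 `COc1ccc2c(c1)OC(c1cc(OC)c(OC)c(OC)c1)C(C(=O)NC(C)(C)C)=C2` carries the (tert-butyl)carbamoyl group on the shared core. Among the compounds with values here, in a functional assay for inhibition of nuclear factor NF-kappa-B complex (Homo sapiens) (a lower number here means a stronger inhibitor, a higher number a weaker inhibitor), compound 1 gives 28400 nM, the highest of the three numbers measured so far. Compound 2 `COc1ccc2c(c1)OC(c1cc(OC)c(OC)c(OC)c1)C(C(=O)N(C)OC)=C2` gives 11700 nM in this assay, and compound 3 `COc1ccc2c(c1)OC(c1cc(OC)c(OC)c(OC)c1)C(C(=O)Nc1ccccc1)=C2` gives 17500 nM. Among these, a 2.4-fold lower number from compound 1 to compound 2 (0.39 log units; beyond the scatter) lies beyond the scatter, while a 1.6-fold lower number from compound 1 to compound 3 (0.21 log units; within the scatter) and a 1.5-fold higher number from compound 2 to compound 3 (0.17 log units; within the scatter) lie within it.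

Compound 4 `COc1ccc2c(c1)OC(c1cc(OC)c(OC)c(OC)c1)C(C(=O)N(C)C)=C2` has not yet been measured. Against compound 1 the difference is dimethylamino in place of (tert-butyl)amino on a carbonyl carbon. Both measured steps from compound 1 exchange the group on the same carbonyl carbon and both lower the number, the larger of them being the step to compound 2, a 2.4-fold lower number from compound 1 to compound 2 (0.39 log units; beyond the scatter). On that basis a modest lowering is expected for compound 4 as well, a 1.9-fold lower number from compound 1 to compound 4 (0.28 log units; within the scatter), though it may fall within the scatter. The estimate for compound 4 in this assay is 15000 nM, with a range from 6000 nM to 40000 nM.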

Compound 4, half-maximal inhibitory concentration: > 50000 nM
Compound 4 was reported as a limit; the forecaster's own chance of this, stated with the estimate: 5%; middle value at least 3.3-fold (0.52 log units) from the limit.
By their numbers in this assay, from the lowest: compounds 2, 3 and 1 (each within the scatter of the next, the first and the last beyond it). At a limit, above all of these: compound 4.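

Compound 4 is the only limit in the series in this assay: the limit of > 50000 nM in this assay, at which 1 of the 4 values shown sits.

Dimethylamino in place of (tert-butyl)amino gives an at least 1.7-fold higher number from compound 1 to compound 4 (0.24 log units; that floor lies within the scatter), so that step alone fixes no direction, but the other two steps lie beyond the scatter: an at least 2.8-fold higher number from compound 3 to compound 4 (0.45 log units; beyond the scatter), and an at least 4.2-fold higher number from compound 2 to compound 4 (0.63 log units; beyond the scatter). Compound 2 and compound 4 both lack the amide hydrogen yet still separate beyond the scatter, so the presence or absence of that hydrogen does not sort these compounds, and methyl in place of methoxy on the amide-type nitrogen is a change this position registers.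

On these data alone, the true value for compound 4 remains open. Also open, as far as these compounds go, is whether other groups on this carbonyl carbon, such as a morpholine amide, a longer alkoxy on the nitrogen or the free carboxylic acid, side with compound 2 or compound 4.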